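The source may report more compounds than this note shows. Statements on the series, on what has been measured and on what is new or still open speak of the compounds shown alone.

Working notes on the series, read in a functional assay on KB cells (Homo sapiens) for cytotoxicity; a lower number here means a stronger inhibitor, a higher number a weaker inhibitor. Compound 1 (`COc1ccc2c(c1)C(=O)C=CC2=O`) gives 33900 nM, and compound 2 (`O=C1C=CC(=O)c2cc(OCc3ccccc3)ccc21`) gives 26200 nM. These two numbers lie within the scatter of each other, so compound 2 stands level with compound 1 and is not separated from it.

Next in the series is compound 3 (`CCOc1ccc2c(c1)C(=O)C=CC2=O`). Its difference from compound 2 is methyl in place of phenyl on a saturated chain carbon bound to an oxygen on an aromatic ring.

Among the measured compounds shown here, only one measured step bears on this change, and it concerns the same place: a 1.3-fold lower number from compound 1 to compound 2 (0.11 log units; within the scatter). There, phenyl replaced hydrogen without a step beyond the scatter. For the measured compounds named here, no measured compound yet carries methyl at this place, so the expectation rests on that single step. On the evidence of a 1.3-fold lower number from compound 1 to compound 2 (0.11 log units; within the scatter), no step beyond the scatter is expected in this assay, in either direction.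

The estimated step is a 1.1-fold higher number from compound 2 to compound 3 (0.06 log units; within the scatter). For compound 3 the estimate is 30000 nM, with an expected range of 15000 nM to 60000 nM.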

Compound 3, half-maximal inhibitory concentration: 21400 nM
For compound 3 the middle estimate is 1.4-fold (0.15 log units) above the measured one, within the range that was stated.
By their numbers in this assay, from the lowest: compounds 3, 2 and 1 (each within the scatter of the next).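

In this assay, the change of phenyl to methyl on a saturated chain carbon bound to an oxygen on an aromatic ring gives a 1.2-fold lower number from compound 2 to compound 3 (0.09 log units; within the scatter), so removing a six-membered aromatic ring and going from 6 heavy atoms to 1 does not separate the two compounds. Methyl in place of hydrogen at the same place, the comparison that was missing before, gives a 1.6-fold lower number from compound 1 to compound 3 (0.20 log units; within the scatter), and compounds 1, 2 and 3 therefore stand level here, with hydrogen, methyl and phenyl on this carbon all giving numbers within the scatter of one another. No supporting data are available that could explain why these three groups remain level.

The compounds shown contain only carbon-based groups without a charge on this carbon, so it remains open whether an amine, a carboxylic acid or a longer chain at the same place would give a step beyond the scatter in this assay. Changes elsewhere on the shared core also remain open, as all three compounds differ only at this one place.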